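The source may report more compounds than this note shows. Statements on the series, on what has been measured and on what is new or still open speak of the compounds shown alone.

Compound 3, `Cc1cc(OC(C)C)c(S(C)(=O)=O)cc1C(=O)N=C(N)N`, is one of three compounds tested in a functional assay for inhibition of sodium/hydrogen exchanger (Oryctolagus cuniculus) (on this read-out higher numbers stand for weaker inhibition and lower numbers for stronger inhibition), where compound 3 gives 19 nM. Compound 2, `Cc1cc(-c2ccccc2)c(S(C)(=O)=O)cc1C(=O)N=C(N)N`, gives 19 nM in this assay, and the two are level: no change at the digits printed from compound 2 to compound 3 (within the scatter). Compound 1, `CCC(C)c1cc(C)c(C(=O)N=C(N)N)cc1S(C)(=O)=O`, gives 8 nM, and the two steps that replace its sec-butyl on an aromatic carbon, a 2.4-fold higher number from compound 1 to compound 2 (0.38 log units; beyond the scatter) and a 2.4-fold higher number from compound 1 to compound 3 (0.38 log units; beyond the scatter), are modest. Compound 4, `Cc1cc(OC2CCCCC2)c(S(C)(=O)=O)cc1C(=O)N=C(N)N`, has not yet been measured. It differs from compound 3 in one place: cyclohexyl in place of isopropyl on an oxygen on an aromatic ring. Among the compounds with values here, no measured step alters the group on this oxygen, so none bears directly on the change; the nearest guide is that exchanging the group on the aromatic carbon among compounds 1, 2 and 3 moved the numbers only modestly or not beyond the scatter. A step of similar size, or none beyond the scatter, is therefore expected for compound 4. The estimate for compound 4 is 19 nM, with a range from 8 nM to 50 nM, which corresponds to an expected step of no change at the digits printed from compound 3 to compound 4 (within the scatter).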

Compound 4, half-maximal inhibitory concentration: 37 nM
Estimate against measurement, compound 4: 1.9-fold (0.29 log units) below, within the range that was stated.
By their numbers in this assay, from the lowest: compound 1; then compounds 2, 3 and 4 (each within the scatter of the next).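

In this assay, replacing the isopropyl on this oxygen with the larger, ring-shaped cyclohexyl gives a step that stays within the scatter (a 1.9-fold higher number from compound 3 to compound 4 (0.29 log units; within the scatter)), so these two groups cannot be told apart on this read-out. This is the first step shown that alters the group on the oxygen itself, and here the larger group brings no change beyond the scatter. Compound 4 also stays within the scatter of the phenyl compound (a 1.9-fold higher number from compound 2 to compound 4 (0.29 log units; within the scatter)), but its gap from the sec-butyl compound is modest and beyond it (a 4.6-fold higher number from compound 1 to compound 4 (0.67 log units; beyond the scatter)).

Within the data shown here, with only two groups on this oxygen, it remains open whether a methyl or a longer chain ending in an amine would shift the number beyond the scatter. Nothing available here explains the sizes of these steps.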